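Replacing 1H-indazol-5-yl with 1-benzothiophen-2-yl in compound 3

This account rests on a few compounds, and the source may have more. Where it says the series, first, only, none or still open, it means among the compounds named here.

For the measured compounds named here, in an ADME assay (liver) for metabolic stability, with Liver microsome (Rattus norvegicus) as the target, using microsomes and NADPH, with a stated time of 30 min, tested at 1 uM (on this read-out higher numbers stand for fast clearance and lower numbers for slow clearance), compound 1 (`Nc1ccc(S(=O)(=O)N2CCN(c3ncc(C(O)(C(F)(F)F)C(F)(F)F)cc3-c3ccncc3)CC2)cn1`) gives 31 mL.min-1.g-1 and compound 2 (`Nc1ccc(S(=O)(=O)N2CCN(c3ncc(C(O)(C(F)(F)F)C(F)(F)F)cc3-c3ccc4[nH]ncc4c3)CC2)cn1`) gives 88 mL.min-1.g-1 as the highest of the two numbers so far. Compound 3 (`Nc1ccc(S(=O)(=O)N2CCN(c3ncc(C(O)(C(F)(F)F)C(F)(F)F)cc3-c3cc4ccccc4s3)CC2)cn1`) has 1-benzothiophen-2-yl in place of 1H-indazol-5-yl on an aromatic carbon. Going by the values given here, the only measured step at this place (a 2.8-fold higher number from compound 1 to compound 2 (0.45 log units; beyond the scatter)) put 1H-indazol-5-yl in place of pyridin-4-yl and was modest. Among the compounds with values here, no measured compound yet carries 1-benzothiophen-2-yl, so no clear direction can be drawn from the data, and no step beyond the scatter is expected in this assay here. The estimated step (a 1.4-fold higher number from compound 2 to compound 3 (0.13 log units; within the scatter)) is therefore small. For compound 3 the expected value is 120 mL.min-1.g-1 (estimated range 50 mL.min-1.g-1 to 280 mL.min-1.g-1).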

Compound 3, intrinsic clearance in microsomes: 315 mL.min-1.g-1
Beside the measured number, compound 3's estimate is 2.6-fold (0.42 log units) below it; measured number outside the range, above it.
By their numbers in this assay, from the lowest: compound 1; then compound 2; then compound 3.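

Swapping one fused ring pair for another of the same heavy-atom count at this aromatic carbon still moves the read-out in this assay, with a 3.6-fold higher number from compound 2 to compound 3 (0.55 log units; beyond the scatter) in this step. Across the three groups at this one position the change reaches a 10-fold higher number from compound 1 to compound 3 (1.01 log units; beyond the scatter), which makes this a place where the choice of group matters greatly, with pyridin-4-yl giving the lowest number and 1-benzothiophen-2-yl the highest. Nothing measured here gives a reason for this order. Going by these compounds, it remains open whether a phenyl ring carrying an amine or a carboxylic acid at this position would give a number nearer to that of compound 1 or to that of compound 3.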